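Methoxy in place of chloro on compound 3

A few compounds are considered here, and "the series" means these few. Any claim that something is new, unique, unknown or untested is made for them only; others in the source may bear on it.

Measured compounds in an assay on isolated protein for inhibition of Amine oxidase [flavin-containing] B (Homo sapiens); a higher number here means a weaker inhibitor, a lower number a stronger inhibitor:
- compound 1, `C#CCNC1CCc2c(SCCc3ccc(Br)cc3)cccc21`, gives 85300 nM
- compound 2, `C#CCNC1CCc2c(SCCc3cccc(C(F)(F)F)c3)cccc21`, gives 3720 nM
- compound 3, `C#CCNC1CCc2c(SCCc3cccc(Cl)c3)cccc21`, gives 82400 nM

Compound 3 stands second highest of the three numbers in this assay. Its nearest neighbour is compound 1, the step being a 1.0-fold lower number from compound 1 to compound 3 (0.02 log units; within the scatter). Going by the values given here, the only step that carries it far is the one from compound 2: a 22-fold higher number from compound 2 to compound 3 (1.35 log units; beyond the scatter), a large change from a single swap on an aromatic carbon.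

Compound 4, `C#CCNC1CCc2c(SCCc3cccc(OC)c3)cccc21`, is not yet measured. It differs from compound 3 by methoxy in place of chloro on an aromatic carbon. Among the compounds with values here, no measured pair puts a methoxy against a chloro here; the one comparison of two groups on that same aromatic carbon is compound 2 against compound 3, which shows that a change at this position can move the number a long way, while compound 1 against compound 3 shows that a halogen swap with a change of position can leave it unmoved. The direction for a methoxy cannot be read from these three alone, so a step near nothing beyond the scatter is expected, with wide uncertainty: a 1.1-fold higher number from compound 3 to compound 4 (0.04 log units; within the scatter). Compound 4 is therefore estimated at 90000 nM, between 20000 nM and 300000 nM.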

Compound 4, half-maximal inhibitory concentration: 28700 nM
For compound 4 the middle estimate is 3.1-fold (0.50 log units) above the measured one, and the stated range covers the measured number.
By their numbers in this assay, from the lowest: compound 2; then compound 4; then compounds 3 and 1 (each within the scatter of the next).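

In this assay, methoxy in place of chloro gives a 2.9-fold lower number from compound 3 to compound 4 (0.46 log units; beyond the scatter) and so shows that this aromatic carbon can also yield a modest change, not only the large one seen with trifluoromethyl. Methoxy does not match trifluoromethyl here, with a 7.7-fold higher number from compound 2 to compound 4 (0.89 log units; beyond the scatter) as the step, so the three groups at this carbon give three separate levels, with trifluoromethyl lowest, methoxy in the middle and chloro highest. The 3-methoxyphenyl group also parts from the 4-bromophenyl group, with a 3.0-fold lower number from compound 1 to compound 4 (0.47 log units; beyond the scatter) as the step, whereas the 3-chlorophenyl group did not.

From the compounds shown here alone, whether a hydroxyl, an ethoxy or a nitrile on this same aromatic carbon would fall within this range remains open. The material shown offers no independent evidence that would explain the order of these three groups.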